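The compounds below may be only part of what the source reports. "The series", "measured", "known", "first", "only" and "open" are said of these compounds alone.

Compound 1 `c1cc([C@H]2CC[C@]3(CC2)OOC2(O3)C3CC4CC(C3)CC2C4)ccc1OCCOC1CCNCC1` gives 50 ug/mL
Compound 2 `CC(C)(N)CCOc1ccc([C@H]2CC[C@]3(CC2)OOC2(O3)C3CC4CC(C3)CC2C4)cc1` gives 50 ug/mL

In a physicochemical assay for solubility, read by nephelometry, measured as kinetic solubility, with a stated time of 30 min (on this read-out higher numbers stand for higher solubility and lower numbers for lower solubility), compound 2 stands at 50 ug/mL and sits level with compound 1 at 50 ug/mL on these numbers. Compound 3 `CC(C)(CN)Oc1ccc([C@H]2CC[C@]3(CC2)OOC2(O3)C3CC4CC(C3)CC2C4)cc1` shares the core and carries this change from compound 2: 1-(aminomethyl)-1-methylethyl in place of 3-amino-3-methylbutyl on an oxygen on an aromatic ring and nothing else. Within the data shown here, the only measured step was no change at the digits printed from compound 1 to compound 2 (within the scatter) and it concerned a different exchange on the chain, which makes it a weak guide. Going by that step alone, no shift beyond the scatter is expected in this assay and the expected move is no change at the digits printed from compound 2 to compound 3 (within the scatter) in size. Compound 3 is estimated at 50 ug/mL within an expected range of 25 ug/mL to 100 ug/mL on this read-out.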

Compound 3, solubility: > 100 ug/mL
Compound 3: only a limit was reported; the forecaster's own chance of this, stated with the estimate: 10%; middle value at least 2.0-fold (0.30 log units) from the limit.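

In this assay, swapping the 3-amino-3-methylbutyl on the aromatic ring's oxygen for 1-(aminomethyl)-1-methylethyl gives an at least 2.0-fold higher number from compound 2 to compound 3 (0.30 log units; that floor lies within the scatter), while the same position, starting from the 2-((piperidin-4-yl)oxy)ethyl chain, gives an at least 2.0-fold higher number from compound 1 to compound 3 (0.30 log units; that floor lies within the scatter). Unlike the earlier pair, which printed level values, these steps show that a change on this oxygen can leave the read-out no longer level. As far as these compounds go, compound 3 is reported only as a limit, > 100 ug/mL, so the true size of both steps stays unknown: the limit of > 100 ug/mL in this assay, at which 1 of the 3 values shown sits.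

From the compounds shown here alone, how far compound 3 truly lies from the other two remains open. Also open, going by these compounds, is how a carboxylic acid or a longer chain carrying an amine on this oxygen would read.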